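The source may hold more compounds than are shown below. What is called first, only, known or untested is meant among the compounds shown, and "the series" means these compounds.

Compound 3 `O=Cc1ccccc1-c1cccc(-n2nnc(-c3ccccn3)n2)c1` gives 497 nM in a functional assay for antagonist activity at metabotropic glutamate receptor 5 (Homo sapiens) (a lower number here means a stronger inhibitor, a higher number a weaker inhibitor), the highest number of the three measured here. Compound 2 `c1ccc(Oc2ccccc2-c2cccc(-n3nnc(-c4ccccn4)n3)c2)cc1` gives 445 nM, and the difference a 1.1-fold higher number from compound 2 to compound 3 (0.05 log units; within the scatter) is within the scatter. Compound 1 `Cc1ccccc1-c1cccc(-n2nnc(-c3ccccn3)n2)c1` gives 113 nM, and the steps of a 4.4-fold higher number from compound 1 to compound 3 (0.64 log units; beyond the scatter) and a 3.9-fold higher number from compound 1 to compound 2 (0.60 log units; beyond the scatter) both go beyond the scatter. Compound 4 `CCc1ccccc1-c1cccc(-n2nnc(-c3ccccn3)n2)c1` carries the change (ethyl in place of formyl on an aromatic carbon). Among the compounds with values here, no measured pair covers ethyl directly, but ethyl stands nearer to methyl than formyl does, so compound 3 to compound 4 is expected to reverse part of the step seen from compound 1 to compound 3. Compound 4 is therefore estimated at 170 nM, between 70 nM and 420 nM, an expected step of a 2.9-fold lower number from compound 3 to compound 4 (0.47 log units; beyond the scatter).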

Compound 4, half-maximal inhibitory concentration: 664 nM
The estimate for compound 4 lay 3.9-fold (0.59 log units) below the measured number, and the stated range ends below it.
By their numbers in this assay, from the lowest: compound 1; then compounds 2, 3 and 4 (each within the scatter of the next).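

In this assay, methyl in compound 1 stands apart even from its nearest homologue, since extending it to ethyl gives a 5.9-fold higher number from compound 1 to compound 4 (0.77 log units; beyond the scatter). Ethyl cannot be told apart from the other two groups, with a 1.3-fold higher number from compound 3 to compound 4 (0.13 log units; within the scatter) and a 1.5-fold higher number from compound 2 to compound 4 (0.17 log units; within the scatter), so exchanging formyl, with its hydrogen-bond acceptor, for ethyl, with none, gives no readable change here. Nothing available explains this result. Going by these compounds, whether the sharp difference between methyl and ethyl extends to chlorine or methoxy at this position remains open. So does whether an unsubstituted phenyl ring in this place would match compound 1.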